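This account rests on a few compounds, and the source may have more. Where it says the series, first, only, none or still open, it means among the compounds named here.

compound 1 `Cc1noc(C)c1-c1ccc2c(c1)c(Cc1ccccc1)cn2CCCCCCC(=O)NO`: 15500 nM
compound 2 `Cc1noc(C)c1-c1ccc2c(c1)c(CCc1ccc(F)cc1)cn2CCCCCC(=O)NO`: 15500 nM

In a functional assay on THP-1 cells (Homo sapiens) for inhibition (a higher number here means a weaker inhibitor of growth, a lower number a stronger inhibitor of growth), compound 2 gives 15500 nM, level with compound 1. Compound 3 `Cc1noc(C)c1-c1ccc2c(c1)c(CCc1ccc(F)cc1)cn2CCCCCCC(=O)NO` differs from compound 2 in one place: (hydroxycarbamoyl)methyl in place of hydroxycarbamoyl on a saturated chain carbon, five bonds along the chain from an aromatic nitrogen. It carries (hydroxycarbamoyl)methyl in place of hydroxycarbamoyl on a saturated chain carbon, five bonds along the chain from an aromatic nitrogen. Among the compounds with values here, no measured pair shows this change alone, but compound 1 and compound 2 differ in more than one place and still sit level, so no step beyond the scatter is expected. The estimated shift is a 1.2-fold lower number from compound 2 to compound 3 (0.08 log units; within the scatter). For compound 3 the estimate is 13000 nM, with an expected range of 5500 nM to 30000 nM.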

Compound 3, concentration for 50% growth inhibition: 15500 nM
The estimate for compound 3 lay 1.2-fold (0.08 log units) below the measured number; the range from low to high includes it.
By their numbers in this assay, from the lowest: compounds 1, 2 and 3 (each within the scatter of the next).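

In this assay, (hydroxycarbamoyl)methyl in place of hydroxycarbamoyl, on a saturated chain carbon five bonds along the chain from an aromatic nitrogen, gives no change at the digits printed from compound 2 to compound 3 (within the scatter) when read alone. 4-Fluorobenzyl in place of phenyl, on a saturated chain carbon bound to an aromatic carbon, gives no change at the digits printed from compound 1 to compound 3 (within the scatter) as a second single change. Each change can now be read by itself, and neither moves the number beyond the scatter. Going by these compounds, whether a longer chain, or a carboxylic acid in place of hydroxycarbamoyl, would move it remains open. Nothing available explains these flat readings.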